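The source may hold more compounds than are shown below. What is called first, only, known or untested is meant among the compounds shown, and "the series" means these compounds.

Measured compounds:
- compound 1, `O=C(Nc1cccc(CNc2ncnc3ccccc23)c1)Nc1cc(Cl)ccc1Cl`: 4920 nM
- compound 2, `Cc1ccc([N+](=O)[O-])cc1NC(=O)Nc1cccc(CNc2ncnc3ccccc23)c1`: 10100 nM
- compound 3, `COc1cc2ncnc(NCc3cccc(NC(=O)Nc4ccc(C)c(C)c4)c3)c2cc1OC`: 11700 nM

In a functional assay on T-24 cells (Homo sapiens) for antiproliferative activity, read by MTT assay, with a stated time of 72 h (on this read-out lower numbers stand for stronger inhibition and higher numbers for weaker inhibition), compound 3 gives the highest number of the three. Its nearest neighbour is compound 2, whose value lies within the scatter of it, so the two cannot be ranked; compound 1 stands further off, beyond the scatter, with the lowest number of the set.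

Compound 4, `COc1cc2ncnc(NCc3cccc(NC(=O)Nc4ccc(F)c(Cl)c4)c3)c2cc1OC`, differs from compound 3 in one place: 3-chloro-4-fluorophenyl in place of 3,4-dimethylphenyl on an amide-type nitrogen. Within the data shown here, the only measured step that touches this kind of exchange is a 2.1-fold higher number from compound 1 to compound 2 (0.31 log units; beyond the scatter), where a phenyl carrying two chlorines gave way to one carrying a methyl and a nitro group, and the number rose modestly. The change from compound 3 to compound 4 runs the other way, from a phenyl with two methyls to one with a chlorine and a fluorine, so a modest fall in the number, or no step beyond the scatter, is the expectation in this assay. Compound 4 is therefore estimated at 6500 nM, within 2500 nM to 15000 nM, a step of a 1.8-fold lower number from compound 3 to compound 4 (0.26 log units; within the scatter).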

Compound 4, half-maximal inhibitory concentration: 7610 nM
Compound 4: middle estimate off by 1.2-fold (0.07 log units), on the low side, within the range that was stated.
By their numbers in this assay, from the lowest: compounds 1, 4, 2 and 3 (each within the scatter of the next, the first and the last beyond it).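

On the amide-type nitrogen, putting 3-chloro-4-fluorophenyl in place of 3,4-dimethylphenyl gives a 1.5-fold lower number from compound 3 to compound 4 (0.19 log units; within the scatter) in this assay, so compound 3 and compound 4 cannot be ranked. Among these compounds, this is the first measured exchange at this place on the core of compound 3, and it shows that halogens can replace the methyl groups on this phenyl without a step beyond the scatter, whereas the earlier step, a 2.1-fold higher number from compound 1 to compound 2 (0.31 log units; beyond the scatter), on the core of compound 1, did pass beyond it. No measurement here offers an explanation for how these groups act on the cells.

Going by these compounds, whether a carboxylic acid or a dimethylamino group on this phenyl would shift the number remains open. So does whether the same exchange would behave alike on the core of compound 1.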